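Removing One Methoxy Group from a Chalcone-Pyrazole Series

The source may report more compounds than this note shows. Statements on the series, on what has been measured and on what is new or still open speak of the compounds shown alone.

Of the compounds shown here, two of a shared core have been tested. Compound 1 `COc1ccc(-c2cc(/C=C/C(=O)c3ccc(N)cc3)[nH]n2)cc1` carries a single methoxy group, and compound 2 `COc1cc(-c2cc(/C=C/C(=O)c3ccc(N)cc3)[nH]n2)cc(OC)c1OC` carries three. In a functional assay on U-251 cells (Homo sapiens) for cytotoxicity, read by sulforhodamine B assay, with a stated time of 48 h, tested at 0.01 uM (on this read-out higher numbers stand for a weaker effect at the one concentration tested and lower numbers for a stronger effect), compound 1 gives 97%. In this assay compound 2 gives 98%. Both numbers sit near the top of the scale, meaning little effect at this concentration, and the two values lie within the scatter of each other, so they cannot be told apart. Compound 3 `COc1ccc(-c2cc(/C=C/C(=O)c3ccc(N)cc3)[nH]n2)cc1OC` remains to be measured. Compared with compound 2, the change is hydrogen in place of methoxy on an aromatic carbon. With the two known compounds looking alike, the expectation is that this change leaves the picture unchanged, and the step of a number 1 percentage points lower from compound 2 to compound 3 (within the scatter) is expected to stay within the scatter. Compound 3 is therefore estimated to give about 97% in this assay, likely between 88% and 102%.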

Compound 3, a percentage reported as activity, at one concentration (the size of the read-out at that concentration, not a potency): 95%
For compound 3 the middle estimate is 2 percentage points above the measured one; the measured number falls inside the stated range.
By their numbers in this assay, from the lowest: compounds 3, 1 and 2 (each within the scatter of the next).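

In this assay, hydrogen in place of methoxy at this position, ortho to a methoxy group, gives a number 3 percentage points lower from compound 2 to compound 3 (within the scatter) within a three-methoxy setting, while methoxy in place of hydrogen gives a number 2 percentage points lower from compound 1 to compound 3 (within the scatter) when starting from a single methoxy group. Compound 1 and compound 2 differ in more than one place, so only these new steps follow a single methoxy group on its own, and from both directions neither goes beyond the scatter. Nothing measured here offers an explanation for this result.

On these data alone, whether a different group at this position, such as a hydroxyl, an amine or a fluorine atom, would move the read-out remains open. So does whether these methoxy changes would still look this small at a higher concentration, where the read-out might leave the top of its scale.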